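The compounds below may be only part of what the source reports. "The series", "measured", "known", "first", "only" and "open" are said of these compounds alone.

Series notes. Compound 1 `CC(C)c1c(Cc2c(Cl)cccc2Cl)nc(SCC(=O)c2ccc(F)cc2)[nH]c1=O` and compound 2 `COc1ccc(C(=O)CSc2nc(Cc3c(Cl)cccc3Cl)c(C(C)C)c(=O)[nH]2)cc1` share one core; compound 3 `O=C(CSc1nc(Cc2c(F)cccc2Cl)cc(=O)[nH]1)c1ccc(F)cc1` and compound 4 `COc1ccc(C(=O)CSc2nc(Cc3c(F)cccc3Cl)cc(=O)[nH]2)cc1` share another, and the difference between the two cores is not broken down here. In an ADME assay on MT4 cells (Homo sapiens) for cytotoxicity, read by MTT assay (on this read-out higher numbers stand for lower toxicity in this test and lower numbers for higher toxicity in this test), compound 1 gives only a limit, > 54000 nM. In this assay compound 2 also gives only a limit, > 14000 nM. The change methoxy in place of fluoro on an aromatic carbon thus reads as a step that the two limits leave unreadable from compound 1 to compound 2, since both values sit at limits, the limit of > 54000 nM in this assay, at which 1 of the 3 values shown sits, and (the limit of > 14000 nM in this assay, at which 1 of the 3 values shown sits). In this assay compound 3 likewise gives only a limit, > 61000 nM, as recorded by the limit of > 61000 nM in this assay, at which 1 of the 3 values shown sits. Compound 4 carries the same change, (methoxy in place of fluoro on an aromatic carbon), on the core of compound 3. The expected step from compound 3 onward is an at least 1.0-fold lower number from compound 3 to compound 4 (0.00 log units; that floor lies within the scatter). This expectation rests on compound 3 sitting at a limit, > 61000 nM, and on no readable movement in the other pair. Compound 4 is expected to give about 60000 nM, most likely again only a limit, between 20000 nM and 200000 nM.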

Compound 4, half-maximal cytotoxic concentration: > 12000 nM
Compound 4 ended at the assay's limit; the forecaster's own chance of this, stated with the estimate: 75%; the middle value does not contradict the limit.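

In this assay compound 3 gives only a limit, > 61000 nM. Compound 4 also gives only a limit, > 12000 nM, so no step can be read for this pair. The compounds shown leave open whether methoxy in place of fluoro changes this read-out on either core.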